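Furan-2-yl for ethynyl on a fused nucleoside core

This account rests on a few compounds, and the source may have more. Where it says the series, first, only, none or still open, it means among the compounds named here.

Measured so far:
compound 1 `COc1ncnc2c1c(-c1ccco1)cn2[C@@H]1O[C@H](CO)[C@@H](O)[C@H]1O`: 430 nM
compound 2 `C#Cc1cn([C@@H]2O[C@H](CO)[C@@H](O)[C@H]2O)c2nc(N)nc(OC)c12`: > 100000 nM

In an ADME assay on BJ cells (Homo sapiens), read by MTT assay, with a stated time of 72 h (on this read-out lower numbers stand for stronger inhibition and higher numbers for weaker inhibition), compound 1 gives 430 nM. For compound 2 the assay reports only a limit, > 100000 nM, so compound 2 stands at the limit of > 100000 nM in this assay, at which 1 of the 2 values shown sits, and no number is known for it. Compound 3 `COc1nc(N)nc2c1c(-c1ccco1)cn2[C@@H]1O[C@H](CO)[C@@H](O)[C@H]1O` is not yet measured; it arises from compound 2 by furan-2-yl in place of ethynyl on an aromatic carbon. Among the measured compounds shown here, no measured step carries this change. Compound 1, which bears the furan-2-yl, sits far from the limit, so a large gain in potency, well beyond the scatter, is expected across this assay, an at least 66-fold lower number from compound 2 to compound 3 (1.82 log units; beyond the scatter). Compound 3 is estimated at 1500 nM, within 300 nM to 20000 nM.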

Compound 3, half-maximal inhibitory concentration: > 100000 nM
Compound 3: no number, only a limit; the forecaster's own chance of this, stated with the estimate: 15%; middle value at least 66-fold (1.82 log units) away from the limit.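

In this assay, the furan-2-yl does not by itself keep the number low: amino in place of hydrogen on an aromatic carbon gives an at least 230-fold higher number from compound 1 to compound 3 (2.36 log units; beyond the scatter). On the amino-bearing core, the furan-2-yl for ethynyl step cannot be read. Compound 2 and compound 3 each give only a limit, not a number: the limit of > 100000 nM in this assay, at which 2 of the 3 values shown sit.

Open, on these data alone, is whether a methyl or a dimethylamino group on that same aromatic carbon also ends at a limit. Also open, as far as these compounds go, is whether any group in place of furan-2-yl gives a number on the amino-bearing core in this assay.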